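This account rests on a few compounds, and the source may have more. Where it says the series, first, only, none or still open, it means among the compounds named here.

Working notes on the series. All compounds share the core of compound 1 `COc1ccc(-c2cc3ccccc3nc2/C=C/C(=O)c2ccccc2)cc1` and differ only in the group on the carbonyl carbon. In a functional assay on NCI-H1299 cells (Homo sapiens) for antiproliferative activity, read by XTT assay, with a stated time of 72 h (on this read-out higher numbers stand for weaker inhibition and lower numbers for stronger inhibition), compound 1 gives 1410 nM. Compound 2 `COc1ccc(-c2cc3ccccc3nc2/C=C/C(=O)c2ccsc2)cc1` carries thiophen-3-yl there, and in this assay compound 2 gives 1220 nM; the step is a 1.2-fold lower number from compound 1 to compound 2 (0.06 log units; within the scatter). Compound 3 `COc1ccc(-c2cc3ccccc3nc2/C=C/C(=O)c2sccc2N)cc1` carries 3-aminothiophen-2-yl. In this assay compound 3 returns > 10000 nM, which is a limit of the assay rather than a number. Compound 3 therefore stands at the weak end of the measured set, the steps into it being an at least 7.0-fold higher number from compound 1 to compound 3 (0.85 log units; beyond the scatter) and an at least 8.1-fold higher number from compound 2 to compound 3 (0.91 log units; beyond the scatter), both beyond the scatter and both ending at the limit of > 10000 nM in this assay, at which 1 of the 3 values shown sits.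

Compound 4 `COc1ccc(-c2cc3ccccc3nc2/C=C/C(=O)c2c[nH]c3ccccc23)cc1` is not yet measured. The change is 1H-indol-3-yl in place of 3-aminothiophen-2-yl on a carbonyl carbon. The measured steps that bear on it are the two into compound 3, which showed that 3-aminothiophen-2-yl on the carbonyl carbon carries the largest loss in the set, whereas phenyl and thiophen-3-yl sit close together. The entering group, like those two, brings no hydrogen-bond acceptor, so the expectation is a return toward the range of compound 1 and compound 2. The expected step is an at least 6.6-fold lower number from compound 3 to compound 4 (0.82 log units; beyond the scatter), a lower number beyond the scatter. Compound 4 is accordingly estimated at 1500 nM in this assay, with a range from 400 nM to 6000 nM.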

Compound 4, half-maximal inhibitory concentration: > 10000 nM
Compound 4: no number, only a limit; the forecaster's own chance of this, stated with the estimate: 15%; middle value at least 6.6-fold (0.82 log units) from the limit.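

In this assay, the loss on the carbonyl carbon is no longer tied to 3-aminothiophen-2-yl alone: 1H-indol-3-yl, which counts 0 hydrogen-bond acceptors where 3-aminothiophen-2-yl counts 2, also brings an at least 8.1-fold higher number from compound 2 to compound 4 (0.91 log units; beyond the scatter) and an at least 7.0-fold higher number from compound 1 to compound 4 (0.85 log units; beyond the scatter). The acceptor count therefore does not separate these two groups in outcome, while both count 1 hydrogen-bond donor, a shared feature that rests on only these two compounds. Compound 4 gives a limit of the assay and not a number, as does compound 3, so the step between them cannot be read and neither can be ranked over the other: the limit of > 10000 nM in this assay, at which 2 of the 4 values shown sit.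

Whether the hydrogen-bond donor matters stays open, since the compounds shown do not separate it from the rest of each group, and a 1-methylindol-3-yl group or an unsubstituted thiophen-2-yl group on the carbonyl carbon would bear directly on this in this assay. Also open, going by these compounds, is whether a fused ring without nitrogen, such as naphthalen-2-yl, would stay with compound 1 and compound 2 or join compound 3 and compound 4 at the limit.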